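The source may report more compounds than this note shows. Statements on the series, on what has been measured and on what is new or still open speak of the compounds shown alone.

Measured in an ADME assay on CHO cells (Cricetulus griseus) for cytotoxicity, read by LDH release (on this read-out lower numbers stand for stronger inhibition and higher numbers for weaker inhibition), each value a limit:
- Compound 1 `CCC(NC(=O)C(C)Oc1ccc(Cl)cc1Cl)c1ccc(F)cc1`: > 100000 nM
- Compound 2 `CCCCC(NC(=O)C(C)Oc1ccc(Cl)cc1Cl)c1ccc(F)cc1`: > 100000 nM
- Compound 3 `CC(Oc1ccc(Cl)cc1Cl)C(=O)NC(c1ccc(F)cc1)C1CCC1`: > 100000 nM

Compound 3 stands at > 100000 nM, which is a limit and not a number. It shares this position with the other two compounds, as the limit of > 100000 nM in this assay, at which 3 of the 3 values shown sit, records.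

Compound 4 `COC(=O)C(NC(=O)C(C)Oc1ccc(Cl)cc1Cl)c1ccc(F)cc1` carries methoxycarbonyl in place of cyclobutyl on a saturated chain carbon bound to an amide-type nitrogen and an aromatic carbon.

Two measured steps changed the group at this same carbon: a step that the two limits leave unreadable from compound 1 to compound 3 and a step that the two limits leave unreadable from compound 2 to compound 3. A third changed the chain there: a step that the two limits leave unreadable from compound 1 to compound 2. None of the three has a readable size, and none brought in methoxycarbonyl. They therefore point in neither direction, and no step beyond the scatter is expected in this assay.

The step expected is a step that the limit leaves unreadable from compound 3 to compound 4. Compound 4 is estimated at 120000 nM, with an expected range from 50000 nM to 300000 nM, and it will most likely be reported as a limit again.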

Compound 4, half-maximal inhibitory concentration: > 100000 nM
Compound 4: no number, only a limit (the forecaster's own chance of this, stated with the estimate: 85%); the middle value does not contradict the limit.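

In this assay compound 4 gives > 100000 nM, which is again a limit and not a number. No step from compound 1, compound 2 or compound 3 to compound 4 can be read: the limit of > 100000 nM in this assay, at which 4 of the 4 values shown sit.

The compounds shown leave open whether any group on the saturated chain carbon bound to an amide-type nitrogen and an aromatic carbon would give a measurable value in this assay.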